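The compounds below may be only part of what the source reports. "The series", "measured", "known", "first", "only" and "open" are said of these compounds alone.

Compound 1, `Cc1nc2cc(-c3ccccc3)nn2c(-c2cc(F)c3c(c2C)CCCO3)c1C(OC(C)(C)C)C(=O)O`: 97%
Compound 2, `Cc1ccc(-c2cc3nc(C)c(C(OC(C)(C)C)C(=O)O)c(-c4cc(F)c5c(c4C)CCCO5)n3n2)cc1`: 94%

In an ADME assay on microsomes from liver (Rattus norvegicus), read by LC-MS, using NADPH, with a stated time of 10 min, tested at 0.5 uM (a higher number here means that more of the compound is left, a lower number that less of the compound is left), compound 2 gives 94%, and compound 1 gives 97%. The step of a number 3 percentage points lower from compound 1 to compound 2 (within the scatter) is within the scatter, so the two compounds cannot be told apart on these numbers; compound 2 simply sits alongside compound 1 near the top of the scale, where nearly all of the compound is still present after the incubation.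

Compound 3, `Cc1nc2cc(-c3ccc(OCc4ccccc4)cc3)nn2c(-c2cc(F)c3c(c2C)CCCO3)c1C(OC(C)(C)C)C(=O)O`, is the next member of the series. It differs from compound 2 in one place: benzyloxy in place of methyl on an aromatic carbon

Among the measured compounds shown here, the only measured step, a number 3 percentage points lower from compound 1 to compound 2 (within the scatter), touched the same aromatic carbon, putting a methyl there in place of hydrogen, and it moved the number by an amount within the scatter. For the measured compounds named here, the present change is of a different kind and size, a benzyloxy group in place of methyl, and no measured pair shows what such a group does here. With both measured compounds near full recovery, the number for compound 3 can hardly rise; it may hold or fall somewhat. The step is therefore expected to be a number 9 percentage points lower from compound 2 to compound 3 (within the scatter), a modest decrease. Compound 3 is estimated at 85%, within 60% to 98%.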

Compound 3, percent of the compound remaining: 79%
Beside the measured number, compound 3's estimate is 6 percentage points above it; measured number inside the range.
By their numbers in this assay, from the lowest: compound 3; then compounds 2 and 1 (each within the scatter of the next).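

The aromatic carbon para to a large group is not indifferent to what it carries. In this assay, among the compounds shown here, methyl in place of hydrogen gave a number 3 percentage points lower from compound 1 to compound 2 (within the scatter), whereas benzyloxy gives a number 15 percentage points lower from compound 2 to compound 3 (beyond the scatter) and, measured against the hydrogen of the first compound, a number 18 percentage points lower from compound 1 to compound 3 (beyond the scatter), so a larger group at this same carbon produces the first change in these compounds that can be told apart from the scatter. The fall is modest, since compound 3 still gives 79%, and nothing available here bears on why the number drops at this position.

Going by these compounds, what stays open is which part of the benzyloxy group goes with the lower number, the oxygen attached to the ring or the benzyl part beyond it. A methoxy group, a hydroxyl or an amine on the same carbon would help separate these, and a longer chain between the oxygen and the outer ring would show whether the number keeps falling as the group grows.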